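The source may report more compounds than this note shows. Statements on the series, on what has been measured and on what is new or still open speak of the compounds shown alone.

Within the data shown here, in a functional assay on A2780 cells (Homo sapiens) for cytotoxicity, read by MTT assay, with a stated time of 24 h (on this read-out lower numbers stand for stronger inhibition and higher numbers for weaker inhibition), compound 1 (`CCCCC[C@@H](C[C@@H](O)C[C@@H]1CC=CC(=O)O1)OC`) gives 49400 nM and compound 2 (`CCCCC[C@H](C[C@@H](O)C[C@@H]1CC=CC(=O)O1)OC`) gives 54500 nM, so compound 2 stands level with its only measured neighbour, within the usual scatter. Compound 3 (`CCCCC[C@H](C[C@H](O)C[C@@H]1CC=CC(=O)O1)OC`) departs from compound 2 in this way: the two compounds have the same atoms and bonds and differ only in configuration as drawn: 1 of 3 stereo elements differ; a stereocentre at a saturated chain carbon is drawn R in compound 2 and S in compound 3. Among the measured compounds shown here, one measured step bears on this, a 1.1-fold higher number from compound 1 to compound 2 (0.04 log units; within the scatter), and the evidence for comparing them is the fact that compounds 1 and 2 differ only in the configuration as drawn. That step also changed only the drawing at a saturated chain carbon, and it stayed within the scatter. A single step is a thin guide, and a change at another stereocentre could behave differently, so the range is kept wide. No clear shift in either direction is expected in this assay, and the estimated step is a 1.1-fold lower number from compound 2 to compound 3 (0.04 log units; within the scatter). For compound 3 the expected value is 50000 nM, with an estimated range from 22000 nM to 110000 nM.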

Compound 3, half-maximal inhibitory concentration: 22900 nM
Compound 3: the middle estimate sits 2.2-fold (0.34 log units) above what was measured; the range from low to high includes it.
By their numbers in this assay, from the lowest: compound 3; then compounds 1 and 2 (each within the scatter of the next).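

In this assay, this saturated chain carbon shows what the earlier stereocentre did not: a 2.4-fold lower number from compound 2 to compound 3 (0.38 log units; beyond the scatter), a modest step beyond the scatter, whereas the earlier change at a different stereocentre, a 1.1-fold higher number from compound 1 to compound 2 (0.04 log units; within the scatter), stayed within it. Compound 3 also stands apart when two stereocentres differ at once, with a 2.2-fold lower number from compound 1 to compound 3 (0.33 log units; beyond the scatter), again a modest step. Configuration alone accounts for the shift between the closest pair, as no atom or bond changes: the fact that compounds 2 and 3 differ only in the configuration as drawn

The compounds shown leave open whether the same effect appears when this carbon is drawn S and the earlier stereocentre is also drawn S, as in neither compound 2 nor compound 3. They also leave open how an amine at this carbon, or a longer chain on the shared core, would behave.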